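A diacid replaces a diol on the amide nitrogen

This account rests on a few compounds, and the source may have more. Where it says the series, first, only, none or still open, it means among the compounds named here.

Measured so far:
Compound 1, `CCn1c(C(=O)NC(C)(C)CO)ccc1C(CC)(CC)c1ccc(OCS(=O)(=O)c2ccccc2)c(C)c1`: 9850 nM
Compound 2, `CCn1c(C(=O)N[C@@H](CO)CCO)ccc1C(CC)(CC)c1ccc(OCS(=O)(=O)c2ccccc2)c(C)c1`: 14100 nM

In a functional assay on PC-3 cells (Homo sapiens) for antiproliferative activity, read by MTT assay, with a stated time of 24 h (a higher number here means a weaker inhibitor, a lower number a stronger inhibitor), compound 2 gives 14100 nM, the highest of the two numbers, though it is separated from compound 1 only by a 1.4-fold higher number from compound 1 to compound 2 (0.16 log units; within the scatter). Compound 3, `CCn1c(C(=O)N[C@H](CCC(=O)O)C(=O)O)ccc1C(CC)(CC)c1ccc(OCS(=O)(=O)c2ccccc2)c(C)c1`, has not yet been measured in this assay. Its difference from compound 2 is 1,3-dicarboxypropyl in place of 3-hydroxy-1-(hydroxymethyl)propyl on an amide-type nitrogen.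

Among the measured compounds shown here, the single measured step bears on this change only loosely: a 1.4-fold higher number from compound 1 to compound 2 (0.16 log units; within the scatter) exchanged one hydroxyl-bearing group for another on the same amide-type nitrogen, and it stayed within the scatter. For the measured compounds named here, no measured step puts a carboxylic acid, let alone two, at that position, so the data give no direct guide to the size or direction of the move to compound 3. Given that the one comparable exchange of amide substituent barely moved the number, compound 3 is estimated at 22000 nM in this assay, within a range from 7000 nM to 70000 nM. That estimate corresponds to a 1.6-fold higher number from compound 2 to compound 3 (0.19 log units; within the scatter), a step expected to be modest but more likely upward than downward, given the wide uncertainty.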

Compound 3, half-maximal inhibitory concentration: > 50000 nM
Compound 3: a limit, no number (the forecaster's own chance of this, stated with the estimate: 20%); middle value at least 2.2-fold (0.35 log units) from the limit.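

In this assay compound 3 gives a limit of the assay and not a number: the limit of > 50000 nM in this assay, at which 1 of the 3 values shown sits.

Even so, the limit is enough to give the change a direction, with an at least 3.5-fold higher number from compound 2 to compound 3 (0.54 log units; beyond the scatter) when 1,3-dicarboxypropyl replaces 3-hydroxy-1-(hydroxymethyl)propyl, and an at least 5.0-fold higher number from compound 1 to compound 3 (0.70 log units; beyond the scatter) when it replaces 1-(hydroxymethyl)-1-methylethyl. The two hydroxyl-bearing groups had shown only a 1.4-fold higher number from compound 1 to compound 2 (0.16 log units; within the scatter), so the amide-type nitrogen had given no sign until now that its substituent could shift the number beyond the scatter, and 1,3-dicarboxypropyl is the first group shown to do so.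

Because compound 3 has only a limit, the full size of both steps stays unknown, and the compounds shown cannot separate the effect of the two carboxylic acid groups from that of the larger substituent as a whole. They also leave open how this assay would read with a chain bearing a single carboxylic acid, with the dimethyl ester of the same diacid, or with an amine on this nitrogen.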